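Piperidinyl for Bromo on a Demethylated Benzoylguanidine

This account rests on a few compounds, and the source may have more. Where it says the series, first, only, none or still open, it means among the compounds named here.

Compound 1 `Cc1cc(Br)c(S(C)(=O)=O)cc1C(=O)N=C(N)N` serves as the reference. In a functional assay for inhibition of sodium/hydrogen exchanger (Oryctolagus cuniculus) (a lower number here means a stronger inhibitor, a higher number a weaker inhibitor), compound 1 gives 12 nM. Compound 2 `Cc1cc(N2CCCCC2)c(S(C)(=O)=O)cc1C(=O)N=C(N)N` carries the change (piperidin-1-yl in place of bromo on an aromatic carbon), and in this assay compound 2 gives 21 nM, a step of a 1.8-fold higher number from compound 1 to compound 2 (0.24 log units; within the scatter). Compound 3 `CS(=O)(=O)c1cc(C(=O)N=C(N)N)ccc1Br` differs from compound 1 in its core, namely (hydrogen in place of methyl on an aromatic carbon). In this assay compound 3 gives 180 nM, a step of a 15-fold higher number from compound 1 to compound 3 (1.18 log units; beyond the scatter). Compound 4 `CS(=O)(=O)c1cc(C(=O)N=C(N)N)ccc1N1CCCCC1` is not yet measured; it differs from compound 3 as follows: piperidin-1-yl in place of bromo on an aromatic carbon. This is the same kind of change as from compound 1 to compound 2, though in compound 1 the place is also meta to a methyl group, which compound 3 does not have. Because a 1.8-fold higher number from compound 1 to compound 2 (0.24 log units; within the scatter) was small, the step expected for compound 4 is a 1.7-fold higher number from compound 3 to compound 4 (0.22 log units; within the scatter). In this assay compound 4 is therefore estimated at 300 nM, with a range from 120 nM to 800 nM.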

Compound 4, half-maximal inhibitory concentration: 130 nM
Beside the measured number, compound 4's estimate is 2.3-fold (0.36 log units) above it, within the range that was stated.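

In this assay, piperidin-1-yl in place of bromo on the core without the methyl group is a 1.4-fold lower number from compound 3 to compound 4 (0.14 log units; within the scatter), and this matches the earlier step on the core of compound 1: the same change on two cores in this assay, a 1.8-fold higher number (0.24 log units; within the scatter) from compound 1 to compound 2 and a 1.4-fold lower number (0.14 log units; within the scatter) from compound 3 to compound 4, 2.4-fold (0.38 log units) apart, within the scatter of two such steps. Hydrogen in place of methyl, with piperidin-1-yl present, is a 6.2-fold higher number from compound 2 to compound 4 (0.79 log units; beyond the scatter), and this in turn matches the step seen with bromo present: the same change on two cores in this assay, a 15-fold higher number (1.18 log units; beyond the scatter) from compound 1 to compound 3 and a 6.2-fold higher number (0.79 log units; beyond the scatter) from compound 2 to compound 4, 2.4-fold (0.38 log units) apart, within the scatter of two such steps. Across these four compounds, each change therefore carries from one core to the other, but two cores cannot show that this holds on any further core, and the numbers do not say why either step has its size.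

The compounds shown leave open whether morpholine or a dimethylamino group in place of bromo would follow the same course. They also leave open whether an ethyl group in place of the methyl would give numbers like those seen with methyl.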